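This account rests on a few compounds, and the source may have more. Where it says the series, first, only, none or still open, it means among the compounds named here.

Measured so far:
- compound 1, `Brc1ccc(C2=NN(C3=NC(c4ccccc4)CS3)C(c3cccc4ccccc34)C2)cc1`: 6650 nM
- compound 2, `Clc1ccc(C2=NN(C3=NC(c4ccccc4)CS3)C(c3cccc4ccccc34)C2)cc1`: 9940 nM
- compound 3, `c1ccc(C2=NN(C3=NC(c4ccccc4)CS3)C(c3ccc4ccccc4c3)C2)cc1`: 3860 nM

All three were tested in a functional assay on HeLa cells (Homo sapiens) for inhibition, read by CCK-8 assay, with a stated time of 48 h; a higher number here means a weaker inhibitor, a lower number a stronger inhibitor. Compound 3 gives 3860 nM, the lowest of the three numbers; compound 1, with 6650 nM, lies within the scatter of it, while compound 2, with 9940 nM, lies beyond the scatter. Among the measured compounds shown here, the only measured step between close neighbours is a 1.5-fold higher number from compound 1 to compound 2 (0.17 log units; within the scatter), a change in the halogen on the phenyl ring that leaves the number essentially where it was.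

Compound 4, `c1ccc(C2=NN(C3=NC(c4ccccc4)CS3)C(c3cccc4ccccc34)C2)cc1`, has not yet been measured. It differs from compound 3 by naphthalen-1-yl in place of naphthalen-2-yl on a saturated ring carbon. For the measured compounds named here, no measured step tests this move directly: compounds 1 and 2 carry the naphthalen-1-yl group but also a halogen on the phenyl ring, so their gap to compound 3 cannot be pinned on the naphthyl group alone. With nothing bearing on this change beyond the scatter, a step of no clear direction is expected, and the number for compound 4 is estimated close to that of compound 3, with a 1.3-fold higher number from compound 3 to compound 4 (0.11 log units; within the scatter). Compound 4 is therefore expected to give about 5000 nM in this assay, estimated to lie between 2000 nM and 15000 nM.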

Compound 4, half-maximal inhibitory concentration: 5320 nM
The estimate for compound 4 lay 1.1-fold (0.03 log units) below the measured number, and the stated range covers the measured number.
By their numbers in this assay, from the lowest: compounds 3, 4, 1 and 2 (each within the scatter of the next, the first and the last beyond it).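

In this assay, naphthalen-1-yl in place of naphthalen-2-yl on the saturated ring carbon gives a difference within the scatter (a 1.4-fold higher number from compound 3 to compound 4 (0.14 log units; within the scatter)), so this first direct test does not separate the two ways of attaching the naphthalene unit. Compound 4 also provides the halogen-free partner for compounds 1 and 2: hydrogen in place of chloro (a 1.9-fold lower number from compound 2 to compound 4 (0.27 log units; within the scatter)) and hydrogen in place of bromo (a 1.3-fold lower number from compound 1 to compound 4 (0.10 log units; within the scatter)) both stay within the scatter, so neither halogen can be told apart from hydrogen on that aromatic carbon in this read-out. Nothing available explains these numbers at the level of the molecule.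

As far as these compounds go, all four compounds carry a naphthalene unit on the saturated ring carbon, so it remains open what a smaller group such as plain phenyl, or a phenyl bearing an amine, would do there. On the phenyl ring that carries the halogen, only bromo, chloro and hydrogen appear, which leaves open what a methoxy group or a carboxylic acid would do in that place.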